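The source may hold more compounds than are shown below. What is called first, only, known or untested is meant among the compounds shown, and "the series" means these compounds.

Measured compounds, all in a functional assay on MCF7 cells (Homo sapiens) for inhibition, read by sulforhodamine B assay, with a stated time of 24 h; on this read-out lower numbers stand for stronger inhibition and higher numbers for weaker inhibition:
compound 1, `N#Cc1c(-c2ccccc2)cn(-c2ccc(S(=O)(=O)Nc3nccs3)cc2)c1NC(N)=O`: 8050 nM
compound 2, `CC(=O)Nc1c(C#N)c(-c2ccccc2)cn1-c1ccc(S(=O)(=O)Nc2nccs2)cc1`: 7240 nM
compound 3, `CC(=O)Nc1c(C#N)c(-c2ccccc2)cn1-c1ccc(S(=O)(=O)Nc2ccccn2)cc1`: 11800 nM

In this assay, for the measured compounds named here, compound 2 gives 7240 nM, the lowest of the three numbers, but the step of a 1.1-fold lower number from compound 1 to compound 2 (0.05 log units; within the scatter) and the step of a 1.6-fold higher number from compound 2 to compound 3 (0.21 log units; within the scatter) both fall within the scatter, so no compound of the three stands apart from the others.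

Compound 4, `N#Cc1c(-c2ccccc2)cn(-c2ccc(S(=O)(=O)Nc3nccs3)cc2)c1N1C(=O)CCC1=O`, differs from compound 2 in one place: 2,5-dioxopyrrolidin-1-yl in place of acetamido on an aromatic carbon. The amide hydrogen of compound 2 is lost and the group on the ring closes into the five-membered non-aromatic ring.

Going by the values given here, of the measured steps, only the step of a 1.1-fold lower number from compound 1 to compound 2 (0.05 log units; within the scatter) touches the same group, and it changed merely the substituent on the carbonyl carbon while keeping the amide hydrogen. The step of a 1.6-fold higher number from compound 2 to compound 3 (0.21 log units; within the scatter) concerns the sulfonamide end and does not bear on this change. Among the compounds with values here, no measured step removes the hydrogen-bond donor or introduces a ring at this position, so the expectation rests on the flat behaviour seen so far at this group. For compound 4 a step of a 1.3-fold higher number from compound 2 to compound 4 (0.12 log units; within the scatter) is expected, with a wide range because the change is larger than the step of a 1.1-fold lower number from compound 1 to compound 2 (0.05 log units; within the scatter) that informs it. The estimate for compound 4 in this assay is therefore 9500 nM, between 3500 nM and 28000 nM.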

Compound 4, half-maximal inhibitory concentration: 6710 nM
For compound 4 the middle estimate is 1.4-fold (0.15 log units) above the measured one, and the stated range covers the measured number.
By their numbers in this assay, from the lowest: compounds 4, 2, 1 and 3 (each within the scatter of the next).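

In this assay, 2,5-dioxopyrrolidin-1-yl in place of acetamido gives a 1.1-fold lower number from compound 2 to compound 4 (0.03 log units; within the scatter), so losing the hydrogen-bond donor and adding a five-membered non-aromatic ring on this aromatic carbon, next to the ring nitrogen, leaves the number within the scatter. For the compounds shown here, the same ring in place of ureido gives a 1.2-fold lower number from compound 1 to compound 4 (0.08 log units; within the scatter), and thus ureido, acetamido and 2,5-dioxopyrrolidin-1-yl are not separated at this place, whereas the earlier compounds covered only a change on the carbonyl carbon with the amide hydrogen kept. Nothing in the available data accounts for this flat behaviour.

From the compounds shown here alone, whether a free amine, a carboxylic acid or a longer chain at this place would move the number in this assay beyond the scatter remains open. Also open, going by these compounds, is whether 2,5-dioxopyrrolidin-1-yl would behave the same way with pyridin-2-yl on the sulfonamide nitrogen, as that group appears here only in compound 3, which carries acetamido.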